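A Methoxy Step Carried From One Core to Another

A few compounds are considered here, and "the series" means these few. Any claim that something is new, unique, unknown or untested is made for them only; others in the source may bear on it.

Compound 1 `O=C(CCc1cccc2c1B(O)OC2)Nc1cccc(-c2ccccc2)c1` is the starting point. In a functional assay on SK-OV-3 cells (Homo sapiens) for antiproliferative activity, read by MTT assay, with a stated time of 72 h (on this read-out lower numbers stand for stronger inhibition and higher numbers for weaker inhibition), compound 1 gives 250 nM. Compound 2 `COc1ccc(-c2cccc(NC(=O)CCc3cccc4c3B(O)OC4)c2)cc1` carries the change methoxy in place of hydrogen on an aromatic carbon and in this assay compound 2 gives 48 nM, a step of a 5.2-fold lower number from compound 1 to compound 2 (0.72 log units; beyond the scatter). Compound 3 `COc1cccc(-c2cccc(NC(=O)CCc3ccc4c(c3)COB4O)c2)c1` is built on a different core; the difference between the two cores is not broken down here. In this assay compound 3 stands only at a limit, > 100000 nM. That limit is the limit of > 100000 nM in this assay, at which 1 of the 3 values shown sits. Compound 4 `COc1cc(OC)cc(-c2cccc(NC(=O)CCc3ccc4c(c3)COB4O)c2)c1` is not yet measured and differs from compound 3 by methoxy in place of hydrogen on an aromatic carbon. This is the same kind of change as that from compound 1 to compound 2, but the place is not the same: in compound 4 the new group sits meta to a large group and meta to a methoxy group, whereas in compound 2 it sits para to a large group. The step seen from compound 1 to compound 2 cannot simply be carried over, because compound 3 gives > 100000 nM as a limit rather than a number. The step from compound 3 to compound 4 is therefore expected to be small, a number no higher from compound 3 to compound 4 (the limit leaves the size open). Compound 4 is expected to give about 100000 nM in this assay, most likely again reported as a limit, with a likely range of 20000 nM to 300000 nM.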

Compound 4, half-maximal inhibitory concentration: 93000 nM
For compound 4 the middle estimate is 1.1-fold (0.03 log units) above the measured one; the range from low to high includes it.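

In this assay compound 3 stands only at a limit, > 100000 nM. The step to its methoxy partner therefore has only a floor, an at least 1.0-fold lower number from compound 3 to compound 4 (0.03 log units; that floor lies within the scatter), and this does not show whether the change does as much on the core of compound 3 as it does on the core of compound 1, nor does it show that the change fails there. Set side by side, and with the added methoxy sitting at a different place on the ring in each pair, the two steps read as follows: the same change on two cores in this assay, a 5.2-fold lower number (0.72 log units; beyond the scatter) from compound 1 to compound 2 and an at least 1.0-fold lower number (0.03 log units; that floor lies within the scatter) from compound 3 to compound 4; the limit leaves it open whether they differ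

The compounds shown leave open how the 3,5-dimethoxyphenyl group would behave on the core of compound 1, which would test the change at this place on that core. They also leave open whether an amine or a carboxylic acid on the outer phenyl ring, or a longer chain before the amide, would move the core of compound 3 away from the limit.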